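Shifting the nitrophenyl group from compound 3 to compound 4

This account rests on a few compounds, and the source may have more. Where it says the series, first, only, none or still open, it means among the compounds named here.

Compound 1 `COc1ccc(NC(=O)NCCNS(=O)(=O)c2ccc(-c3ccccc3OCc3ccccc3)s2)cc1`: > 50000 nM (a limit)
Compound 2 `COc1cccc(NC(=O)NCCNS(=O)(=O)c2ccc(-c3ccccc3OCc3ccccc3)s2)c1`: > 20000 nM (a limit)
Compound 3 `O=[N+]([O-])c1ccc(NC(=S)NCCNS(=O)(=O)c2ccc(-c3ccccc3OCc3ccccc3)s2)cc1`: 8900 nM

All three compounds were tested in an ADME assay on HEK-293T cells (Homo sapiens) for cytotoxicity, read by CCK-8 assay, with a stated time of 48 h; on this read-out higher numbers stand for weaker inhibition and lower numbers for stronger inhibition. Compound 1 gives only a limit of the assay, > 50000 nM, and no number. Compound 2 also gives only a limit, > 20000 nM, and no number. Compound 3 alone has a true number, 8900 nM, and it stands lowest of the three, as an at least 5.6-fold lower number from compound 1 to compound 3 (0.74 log units; beyond the scatter) and an at least 2.2-fold lower number from compound 2 to compound 3 (0.35 log units; beyond the scatter) show.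

Compound 4 `O=[N+]([O-])c1cccc(NC(=S)NCCNS(=O)(=O)c2ccc(-c3ccccc3OCc3ccccc3)s2)c1` differs from compound 3 by 3-nitrophenyl in place of 4-nitrophenyl on an amide-type nitrogen. For the measured compounds named here, the one measured step of this kind, 3-methoxyphenyl in place of 4-methoxyphenyl, is a step that the two limits leave unreadable from compound 1 to compound 2 and so offers no size to carry over. The two steps to compound 3 swap a whole group, not just its position, so they say little here. The expected change, a 1.0-fold higher number from compound 3 to compound 4 (0.00 log units; within the scatter), is therefore none beyond the scatter. For compound 4 the estimated value is 9000 nM, with an expected range of 4000 nM to 22000 nM.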

Compound 4, half-maximal inhibitory concentration: 18300 nM
Compound 4: the middle estimate sits 2.0-fold (0.31 log units) below what was measured; measured number inside the range.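

In this assay, the change of 3-nitrophenyl for 4-nitrophenyl on the amide-type nitrogen gives a 2.1-fold higher number from compound 3 to compound 4 (0.31 log units; beyond the scatter). For the compounds shown here, this is the first readable size for a change of ring position alone, since the two methoxyphenyl compounds give only limits of the assay and no numbers. Measured against those limits, the new compound shows an at least 2.7-fold lower number from compound 1 to compound 4 (0.43 log units; beyond the scatter) and an at least 1.0-fold lower number from compound 2 to compound 4 (0.03 log units; that floor lies within the scatter), so its lead over the 4-methoxyphenyl compound is clear, while its lead over the 3-methoxyphenyl compound cannot be told apart from the scatter.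

Going by these compounds, it remains open whether a nitrile or a carboxylic acid in place of the nitro group would respond to the same shift in the same way. Nothing shown bears on why this shift raises the number.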